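Methylating a phenol on two related ester cores

The source may hold more compounds than are shown below. What is called first, only, known or untested is meant among the compounds shown, and "the series" means these compounds.

Compound 1 `O=C(/C=C/c1ccc(O)c(O)c1)OCc1c(-c2ccccc2)no[n+]1[O-]` and compound 2 `COc1cc(/C=C/C(=O)OCc2c(-c3ccccc3)no[n+]2[O-])ccc1O` share one core, while compound 3 `O=C(/C=C/c1ccc(OCCCCCCO[N+](=O)[O-])c(O)c1)OCCCCCCO[N+](=O)[O-]` and compound 4 `COc1cc(/C=C/C(=O)OCCCCCCO[N+](=O)[O-])ccc1OCCCCCCO[N+](=O)[O-]` share another; the difference between the two cores is not broken down here. In a functional assay on HeLa cells (Homo sapiens) for cytotoxicity, read by resazurin assay, with a stated time of 72 h (on this read-out lower numbers stand for stronger inhibition and higher numbers for weaker inhibition), compound 1 gives 1230 nM, and compound 2 gives 7820 nM. The change between them is methyl in place of hydrogen on an oxygen on an aromatic ring, and it made a step of a 6.4-fold higher number from compound 1 to compound 2 (0.80 log units; beyond the scatter). Compound 3 gives 1350 nM in this assay, a value close to that of compound 1. Going by the values given here, compound 4 differs from compound 3 by methyl in place of hydrogen on an oxygen on an aromatic ring, the same change in the same place, so the measured step is the only guide to what this change does. Among the compounds with values here, the step from compound 3 to compound 4 is expected to be a 4.4-fold higher number from compound 3 to compound 4 (0.65 log units; beyond the scatter), somewhat smaller than the earlier one, because the only measured example of this change is the step of a 6.4-fold higher number from compound 1 to compound 2 (0.80 log units; beyond the scatter) on a core that differs from that of compound 3 in a way not broken down here. Compound 4 is therefore estimated at 6000 nM, between 2500 nM and 15000 nM in this assay.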

Compound 4, half-maximal inhibitory concentration: > 50000 nM
Compound 4 ended at the assay's limit (the forecaster's own chance of this, stated with the estimate: 5%); middle value at least 8.3-fold (0.92 log units) from the limit.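

Replacing hydroxy with methoxy on the oxygen on the aromatic ring gives an at least 37-fold higher number from compound 3 to compound 4 (1.56 log units; beyond the scatter) in this assay, so the number rises on the core of compound 3 just as it does on the core of compound 1. The direction of the change carries from one core to the other, but its size does not: the same change on two cores in this assay, a 6.4-fold higher number (0.80 log units; beyond the scatter) from compound 1 to compound 2 and an at least 37-fold higher number (1.56 log units; beyond the scatter) from compound 3 to compound 4, at least 5.8-fold (0.76 log units) apart, beyond the scatter of two such steps Compound 4 gives > 50000 nM, which is a limit of the assay and not a number, so its step has no known upper end, and two pairs cannot show which part of the cores sets the gap between the steps.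

From the compounds shown here alone, it remains open whether ethyl on that same oxygen would give a step nearer to the one on the core of compound 1 or the one on the core of compound 3. Going by these compounds, it is also open how large the step from hydroxy to methoxy would be on a third core, for instance one carrying an amine.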